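Cytotoxicity of dinonyl aminosugars with varied anomeric substituents

This account rests on a few compounds, and the source may have more. Where it says the series, first, only, none or still open, it means among the compounds named here.

The measured compounds, with their read-outs in a toxicity assay on the whole organism (J774 cells) for cytotoxicity, with Mus musculus as the target, read by MTT assay, with a stated time of 24 h, tested at 10 uM; on this read-out lower numbers stand for a stronger effect and higher numbers for a weaker effect at the one concentration tested:
compound 1 `C=CCO[C@H]1O[C@H](CN)[C@@H](OCCCCCCCCC)[C@H](OCCCCCCCCC)[C@H]1N` gives 91.4%
compound 2 `CCCCCCCCCO[C@@H]1[C@@H](N)[C@@H](OC[C@@H](O)CN)O[C@H](CN)[C@H]1OCCCCCCCCC` gives 85.1%
compound 3 `CCCCCCCCCO[C@@H]1[C@@H](N)[C@@H](OCC(O)CO)O[C@H](CN)[C@H]1OCCCCCCCCC` gives 89.7%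

In this assay compound 3 stands second highest of the three, nearest to compound 1 and furthest from compound 2, both gaps within the scatter. The steps among the measured compounds are all small: a number 6.3 percentage points lower from compound 1 to compound 2 (within the scatter), a number 1.7 percentage points lower from compound 1 to compound 3 (within the scatter) and a number 4.6 percentage points higher from compound 2 to compound 3 (within the scatter). Each replaces one group on a saturated chain carbon bound to an oxygen on a saturated carbon, and none moves the read-out beyond the scatter.

Compound 4 `CCCCCCCCCO[C@@H]1[C@@H](N)[C@@H](O[C@H]2[C@H](O)[C@@H](O)[C@H](N)C[C@@H]2N)O[C@H](CN)[C@H]1OCCCCCCCCC` differs from compound 3 in another way: 4,6-diamino-2,3-dihydroxycyclohexyl in place of 2,3-dihydroxypropyl on an oxygen on a saturated carbon. For the measured compounds named here, no measured step bears directly on this change, since none of the steps so far exchanges a chain for a ring at this oxygen. With three close values and no step beyond the scatter, compound 4 is expected to stay near the group, so the estimated step is a number 3.7 percentage points lower from compound 3 to compound 4 (within the scatter), with no direction beyond the scatter. Compound 4 is therefore estimated at 86%, within a range from 70% to 97%.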

Compound 4, a percentage reported as activity, at one concentration (the size of the read-out at that concentration, not a potency): 82.7%
The estimate for compound 4 lay 3.3 percentage points above the measured number; the measured number falls inside the stated range.
By their numbers in this assay, from the lowest: compounds 4, 2, 3 and 1 (each within the scatter of the next).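

In this assay, placing 4,6-diamino-2,3-dihydroxycyclohexyl on this oxygen gives a number 7 percentage points lower from compound 3 to compound 4 (within the scatter), a number 2.4 percentage points lower from compound 2 to compound 4 (within the scatter) and a number 8.7 percentage points lower from compound 1 to compound 4 (within the scatter). For the compounds shown here, the earlier compounds carried only open chains here, so compound 4 is the first to show that one six-membered non-aromatic ring of carbon only can stand at this position without moving the read-out beyond the scatter of any of the three compounds. Nothing measured here explains the read-out of compound 4 or separates the contribution of its ring from that of its amino groups.

Left open is whether a carboxylic acid or a guanidine on this oxygen would take the read-out beyond the scatter. From the compounds shown here alone, it also remains open whether a cyclohexyl ring without the amino and hydroxyl groups, or a longer chain in place of the nonyl chains, would do so.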